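Series notes: alkyl removal at the carboxylic acid carbon

The source may hold more compounds than are shown below. What is called first, only, known or untested is meant among the compounds shown, and "the series" means these compounds.

The series is followed in an ADME assay on the whole organism (Mus musculus, strain CD1) for pharmacokinetics, read by LC-MS, with a stated time of 24 h, at a dose of 5 mg/kg by the oral route; on this read-out lower numbers stand for lower exposure and higher numbers for higher exposure at the dose given. Compound 2 `CCC(C(=O)O)c1nn(Cc2cn3cc(OCC4CC4)c(Cl)cc3n2)c2ccccc2c1=O` gives 2210000 nM, the second highest of the three numbers in hand. Compound 3 `CC(C(=O)O)c1nn(Cc2cn3cc(OCC4CC4)c(C(F)(F)F)cc3n2)c2ccccc2c1=O` gives 7240000 nM, a higher number that lies beyond the scatter of the read-out. Compound 1 `O=C(O)Cn1nc(Cc2nc3cc(Cl)c(OCC(F)F)cc3[nH]2)c2ccccc2c1=O` gives 82400 nM, the lowest of the three and furthest from compound 2, also beyond the scatter. Among the compounds with values here, no two measured compounds differ in a single place, so none of these gaps can be tied to one structural change.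

Compound 4 `O=C(O)Cc1nn(Cc2cn3cc(OCC4CC4)c(Cl)cc3n2)c2ccccc2c1=O` is not yet measured. It differs from compound 2 as follows: hydrogen in place of ethyl on a saturated chain carbon bound to an aromatic carbon and a carbonyl carbon. Within the data shown here, there is no measured pair that isolates this change, so the size of its effect is unknown. The working expectation is a moderate fall in exposure, with the estimate of the step being a 2.2-fold lower number from compound 2 to compound 4 (0.34 log units; beyond the scatter). Compound 4 is therefore expected to give about 1000000 nM, with a range from 300000 nM to 3500000 nM.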

Compound 4, maximal plasma concentration: 2010000 nM
Compound 4: the middle estimate sits 2.0-fold (0.30 log units) below what was measured; the range from low to high includes it.
By their numbers in this assay, from the lowest: compound 1; then compounds 4 and 2 (each within the scatter of the next); then compound 3.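

In this assay, within the data shown here, the pair gives the first isolated reading at this position: hydrogen in place of ethyl on a saturated chain carbon bound to an aromatic carbon and a carbonyl carbon gives a 1.1-fold lower number from compound 2 to compound 4 (0.04 log units; within the scatter). On the core shared by these two compounds, the 1-carboxypropyl and carboxymethyl forms therefore cannot be told apart, and the ethyl group is not required for the exposure seen at this dose. Nothing in hand gives a cause for this result.

As far as these compounds go, whether a longer chain such as propyl, or a fluorine atom, on this same carbon would also leave the read-out within the scatter remains open. Also open, from the compounds shown here alone, is whether hydrogen in place of the methyl carried at this carbon by compound 3 would read the same way on the core of compound 3.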